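The source may report more compounds than this note shows. Statements on the series, on what has been measured and on what is new or still open speak of the compounds shown alone.

Compound 2 `O=C(CN1CCCC1)N1CCC(NS(=O)(=O)c2cc(S(=O)(=O)c3ccccc3)ccc2C(F)(F)F)CC1` sits at the bottom of the three measurements so far: in a physicochemical assay for solubility (on this read-out higher numbers stand for higher solubility and lower numbers for lower solubility), compound 2 gives 25000 nM. Compound 1 `CN(C)CC(=O)N1CCC(NS(=O)(=O)c2cc(S(=O)(=O)c3ccccc3)ccc2C(F)(F)F)CC1` gives 100000 nM in this assay, and compound 3 `O=C([C@@H]1CCCN1C(=O)c1ccncc1)N1CCC(NS(=O)(=O)c2cc(S(=O)(=O)c3ccccc3)ccc2C(F)(F)F)CC1` gives 100000 nM. For the measured compounds named here, the only single-site step among the measured compounds is a 4.0-fold lower number from compound 1 to compound 2 (0.60 log units; beyond the scatter), a change of an amine on a saturated chain carbon bound to a carbonyl carbon.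

Compound 4 `CC(C)(C)NC(=O)N1CCC[C@H]1C(=O)N1CCC(NS(=O)(=O)c2cc(S(=O)(=O)c3ccccc3)ccc2C(F)(F)F)CC1` is the next compound in this series. Its difference from compound 2 is 1-((tert-butyl)carbamoyl)pyrrolidin-2-yl in place of (pyrrolidin-1-yl)methyl on a carbonyl carbon. Going by the values given here, no measured step matches this change, and the step from compound 1 to compound 2 concerns a smaller swap; the one guide is compound 3, whose value of 100000 nM belongs to a compound that also carries a pyrrolidin-2-yl group on the carbonyl carbon. On that basis compound 4 is expected to show a 1.6-fold higher number from compound 2 to compound 4 (0.20 log units; within the scatter) in this assay, though the expectation is loose. The estimated solubility for compound 4 is 40000 nM, with a range from 10000 nM to 150000 nM.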

Compound 4, solubility: 50000 nM
Estimate against measurement, compound 4: 1.3-fold (0.10 log units) below; the range from low to high includes it.
By their numbers in this assay, from the lowest: compounds 2, 4, 1 and 3 (each within the scatter of the next, the first and the last beyond it).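

In this assay, the new group on the carbonyl carbon leaves the number within the scatter of both smaller amine-bearing groups: the step is a 2.0-fold higher number from compound 2 to compound 4 (0.30 log units; within the scatter) and, against the dimethylamino side chain, a 2.0-fold lower number from compound 1 to compound 4 (0.30 log units; within the scatter). For the compounds shown here, the result also gives the first reading of a change on the outer carbonyl carbon, where (tert-butyl)amino in place of pyridin-4-yl gives a 2.0-fold lower number from compound 3 to compound 4 (0.30 log units; within the scatter) and so also stays within the scatter. Compound 4 therefore cannot be separated from any of the other three compounds on this read-out, and nothing available accounts for these steps.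

Going by these compounds, whether a carboxylic acid or a longer chain in place of (tert-butyl)amino would move the number beyond the scatter remains open. So does the effect of reversing the defined stereocentre in the 1-((tert-butyl)carbamoyl)pyrrolidin-2-yl group.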